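Ring methyl on compound 3: cytotoxicity outlook

The source may hold more compounds than are shown below. What is called first, only, known or untested is meant among the compounds shown, and "the series" means these compounds.

Compound 3 `COC(=O)[C@H](CO)NC(=O)c1cnc2ccccc2c1Cl` in an ADME assay on CCRF-CEM cells (Homo sapiens) for cytotoxicity (a higher number here means that more compound is tolerated, a lower number that less compound is tolerated), gives > 100 uM, which is a limit of the assay rather than a number. Compound 2 `COC(=O)[C@@H](NC(=O)c1cnc2ccccc2c1Cl)[C@@H](C)O` in this assay likewise gives > 100 uM, again a limit. Compound 1 `COC(=O)[C@H](CSC)NC(=O)c1cnc2ccccc2c1Cl` in this assay gives 68.4 uM. Two of the three values sit at the limit of > 100 uM in this assay, at which 2 of the 3 values shown sit, so compound 3 cannot be ordered against compound 2, and only compound 1 stands at a readable number.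

The measured steps all sit on the side chain: an at least 1.4-fold higher number from compound 1 to compound 2 (0.16 log units; that floor lies within the scatter) and an at least 1.4-fold higher number from compound 1 to compound 3 (0.16 log units; that floor lies within the scatter), while a step that the two limits leave unreadable from compound 2 to compound 3. Compound 4 `COC(=O)[C@H](CO)NC(=O)c1cnc2ccc(C)cc2c1Cl` differs from compound 3 on the ring system instead: methyl in place of hydrogen on an aromatic carbon. No measured step touches that ring, so none of the shown steps bears directly on this change; the side-chain steps show only that this core gives values at or near the top of the measured window. The expectation is accordingly a step of no readable size, a step that the limit leaves unreadable from compound 3 to compound 4, in this assay. Compound 4 is estimated at 120 uM in this assay, between 55 uM and 300 uM, and is most likely to be reported again as a limit.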

Compound 4, half-maximal toxic concentration: > 100 uM
Compound 4: no number, only a limit (the forecaster's own chance of this, stated with the estimate: 70%); the middle value does not contradict the limit.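

In this assay compound 4 gives > 100 uM as a limit of the assay. Compound 3 also stands at a limit, so no step between compound 3 and compound 4 can be read: the limit of > 100 uM in this assay, at which 3 of the 4 values shown sit.

The compounds shown leave open whether methyl in place of hydrogen on an aromatic carbon changes the number in this assay at all.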